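Compound 4: from chloromethyl to phenyl on the ester

A few compounds are considered here, and "the series" means these few. Any claim that something is new, unique, unknown or untested is made for them only; others in the source may bear on it.

Compound 1 `CC(C)c1cc2c3c(c1OC(=O)CCl)OC(=O)[C@@]31CCCC(C)(C)[C@@H]1CC2` gives 130000 nM in an ADME assay on MRC5 cells (Homo sapiens) for cytotoxicity, read by neutral red uptake, with a stated time of 24 h; on this read-out lower numbers stand for stronger inhibition and higher numbers for weaker inhibition
Compound 2 `CCCCCCCCCCCC(=O)Oc1c(C(C)C)cc2c3c1OC(=O)[C@@]31CCCC(C)(C)[C@@H]1CC2` gives > 1000000 nM as a limit
Compound 3 `CCCCC/C=C/C/C=C/CCCCCCCC(=O)Oc1c(C(C)C)cc2c3c1OC(=O)[C@@]31CCCC(C)(C)[C@@H]1CC2` gives 293000 nM in this assay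

Compound 1 has the lowest number in this assay and compound 3 stands nearest to it on the higher side. Compound 4 `CC(C)c1cc2c3c(c1OC(=O)c1ccccc1)OC(=O)[C@@]31CCCC(C)(C)[C@@H]1CC2` departs from compound 1 by phenyl in place of chloromethyl on a carbonyl carbon, with phenyl in place of chloromethyl on a carbonyl carbon. The closest measured change is the one an at least 7.6-fold higher number from compound 1 to compound 2 (0.88 log units; beyond the scatter), where decyl replaces chloro. The change an at least 3.4-fold lower number from compound 2 to compound 3 (0.53 log units; beyond the scatter) alters only the long chain, which compound 4 lacks, so it bears less. Given the rise seen for compound 2 at an at least 7.6-fold higher number from compound 1 to compound 2 (0.88 log units; beyond the scatter), a modest move to a higher number is expected, an estimated 2.2-fold higher number from compound 1 to compound 4 (0.33 log units; beyond the scatter) here. In this assay the estimate for compound 4 is 280000 nM, with an expected range of 100000 nM to 800000 nM at this stage.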

Compound 4, half-maximal inhibitory concentration: 512000 nM
The estimate for compound 4 lay 1.8-fold (0.26 log units) below the measured number; measured number inside the range.
By their numbers in this assay, from the lowest: compound 1; then compounds 3 and 4 (each within the scatter of the next). At a limit, above all of these: compound 2.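

The rise in number from compound 1 does not depend on a long chain. A single six-membered aromatic ring in place of chloromethyl on the same carbonyl carbon also gives one in this assay: a 3.9-fold higher number from compound 1 to compound 4 (0.60 log units; beyond the scatter). Compound 1, the only ester here with chloromethyl, keeps the lowest number. Read against a limit, the remaining step gives only a floor, and that floor lies within the scatter: an at least 1.9-fold lower number from compound 2 to compound 4 (0.29 log units; that floor lies within the scatter). Compound 2 stands at that limit: the limit of > 1000000 nM in this assay, at which 1 of the 4 values shown sits.

As far as these compounds go, whether the chlorine itself matters remains open. A plain methyl on the carbonyl carbon, or a benzoyl ring carrying an amine, would bear on that question.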